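The source may hold more compounds than are shown below. What is called first, only, known or untested is meant among the compounds shown, and "the series" means these compounds.

Compound 2 `CCCN1CCC2(CC1)OC(OC)Cc1c2cnn1C` is known in an assay for displacement of a labelled ligand from Sigma non-opioid intracellular receptor 1 (Cavia porcellus), read by scintillation counting, with a stated time of 180 min (on this read-out lower numbers stand for stronger inhibition and higher numbers for weaker inhibition), only as a limit: compound 2 gives > 1000 nM. Its measured neighbour, compound 1 `COC1Cc2c(cnn2C)C2(CCN(CCCc3ccccc3)CC2)O1`, gives 93 nM in this assay. Within the data shown here, the one step between the two, an at least 10-fold higher number from compound 1 to compound 2 (1.03 log units; beyond the scatter), rests on (the limit of > 1000 nM in this assay, at which 1 of the 2 values shown sits). Compound 3 `COC1Cc2c(cnn2C)C2(CCN(CCC(C)C)CC2)O1` differs from compound 2 by isopropyl in place of methyl on a saturated chain carbon, two bonds along the chain from an amine nitrogen in a ring. Among the measured compounds shown here, the only measured step that bears on this change is the one from compound 1 to compound 2, and it was large, but it concerned the loss of a phenyl at a place three bonds from the amine nitrogen, whereas here an isopropyl enters at a place two bonds from it, a smaller group in a different place. A step in this assay toward lower numbers is plausible but far from assured, and compound 2 offers only a limit to start from. Compound 3 is therefore expected to give about 800 nM, within 250 nM to 2500 nM, an expected step of an at least 1.2-fold lower number from compound 2 to compound 3 (0.09 log units; that floor lies within the scatter).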

Compound 3, inhibition constant: 18 nM
The estimate for compound 3 lay 44-fold (1.65 log units) above the measured number; the whole stated range lies above it.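

In this assay, isopropyl in place of methyl on a saturated chain carbon, two bonds along the chain from an amine nitrogen in a ring, gives an at least 55-fold lower number from compound 2 to compound 3 (1.74 log units; beyond the scatter), so a low number at this place does not depend on a phenyl group. Only a floor can be given for the size of that step, and compound 2 is the compound that stands at a limit: the limit of > 1000 nM in this assay, at which 1 of the 3 values shown sits. At the same place, isopropyl in place of benzyl gives a 5.2-fold lower number from compound 1 to compound 3 (0.71 log units; beyond the scatter), so the small branched group outperforms the larger aromatic one here.

The compounds shown leave open whether the branching or simply the added chain length carries the change, which a straight pentyl chain would help to separate. They also leave open how a cyclohexyl group or a hydroxyl group would fare at this place.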